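This account rests on a few compounds, and the source may have more. Where it says the series, first, only, none or still open, it means among the compounds named here.

Measured in a physicochemical assay for lipophilicity; on this read-out higher numbers stand for higher lipophilicity and lower numbers for lower lipophilicity:
- compound 1 `CCOC(=O)C1=C(C)NC(=S)NC1c1cn(C(=O)CNc2ccccc2)c2ccccc12`: 2.92
- compound 2 `CCOC(=O)C1=C(C)NC(=O)NC1c1cn(C(=O)CNc2ccc([N+](=O)[O-])cc2C)c2ccccc12`: 1.94

Compound 2 is the lower of the two, at 1.94, and its gap to compound 1, at 2.92, lies beyond the scatter. Compound 3 `CCOC(=O)C1=C(C)NC(=O)NC1c1cn(C(=O)CNc2ccc(Cl)cc2)c2ccccc12` has not yet been measured. It carries 4-chlorophenyl in place of 2-methyl-4-nitrophenyl on an amine nitrogen. For the measured compounds named here, no measured pair isolates this change, so the expectation is a judgement anchored on compound 2. An upward move in this assay, beyond the scatter, is expected, and the estimated step is a number 0.66 log units higher from compound 2 to compound 3 (beyond the scatter). The expected value for compound 3 is 2.6, with an estimated range of 2.1 to 3.1.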

Compound 3, partition coefficient: 2.04
Beside the measured number, compound 3's estimate is 0.56 log units above it, and the stated range ends above it.
By their numbers in this assay, from the lowest: compounds 2 and 3 (each within the scatter of the next); then compound 1.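

For the compounds shown here, on the amine nitrogen, 4-chlorophenyl in place of 2-methyl-4-nitrophenyl gives, in this assay, a number 0.10 log units higher from compound 2 to compound 3 (within the scatter) and is the first single-place change readable at this position. The two groups therefore cannot be told apart on this read-out, despite the different heavy-atom counts. No measurement offered here explains this result.

Steps to compound 1 cannot be read, as it differs from compound 2 and compound 3 in more than one place. Open, from the compounds shown here alone, is how a 4-aminophenyl or a 4-carboxyphenyl group would read on this nitrogen.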